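The source may report more compounds than this note shows. Statements on the series, on what has been measured and on what is new or still open speak of the compounds shown alone.

Within the data shown here, compound 3, `O=C1/C(=C\c2ccccc2[N+](=O)[O-])c2ccccc2N1c1c(Cl)cccc1Cl`, gives 1 ug/mL in a functional assay on KB cells (Homo sapiens) for cytotoxicity, read by MTT assay, with a stated time of 72 h (a higher number here means that more compound is needed for the effect, a lower number that less compound is needed), and stands at the lowest of the three numbers measured so far. Its nearest neighbour is compound 2, `O=C1/C(=C\c2cccc(Br)c2)c2ccccc2N1c1c(Cl)cccc1Cl`, which gives 2 ug/mL in this assay, and the furthest is compound 1, `O=C1/C(=C\c2cccc(Oc3ccccc3)c2)c2ccccc2N1c1c(Cl)cccc1Cl`, which gives 5 ug/mL. The path between them runs through a 2.5-fold lower number from compound 1 to compound 2 (0.40 log units; beyond the scatter) and then a 2.0-fold lower number from compound 2 to compound 3 (0.30 log units; within the scatter).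

Compound 4, `O=C1/C(=C\c2cccc(Cl)c2)c2ccccc2N1c1c(Cl)cccc1Cl`, differs from compound 3 in one place: 3-chlorophenyl in place of 2-nitrophenyl on a double-bonded chain carbon bound to a double-bonded ring carbon. Among the measured compounds shown here, the step that bears most directly on this change is the one from compound 2 to compound 3, where 2-nitrophenyl replaced 3-bromophenyl and the number fell only within the scatter. For the measured compounds named here, compound 4 carries 3-chlorophenyl, and the one earlier swap at this position moved the number little, so no step beyond the scatter is expected in this assay, with the value for compound 4 estimated to sit a little above that of compound 3, as a 2.0-fold higher number from compound 3 to compound 4 (0.30 log units; within the scatter). Compound 4 is therefore expected to give about 2 ug/mL, within a range from 1 ug/mL to 5 ug/mL.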

Compound 4, concentration for half-maximal effect: 2 ug/mL
Compound 4: middle estimate and measured number agree at the digits printed, and the stated range covers the measured number.
By their numbers in this assay, from the lowest: compounds 3, 2 and 4 (each within the scatter of the next); then compound 1.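

Compound 2 and compound 4 cannot be told apart in this assay (no change at the digits printed from compound 2 to compound 4 (within the scatter)), with chloro in place of bromo on an aromatic carbon. Chloro in place of phenoxy gives a step beyond the scatter (a 2.5-fold lower number from compound 1 to compound 4 (0.40 log units; beyond the scatter)), of the same printed size as the one for bromo in place of phenoxy (a 2.5-fold lower number from compound 1 to compound 2 (0.40 log units; beyond the scatter)), so compound 1 now stands apart from two halogen-bearing compounds rather than one. Exchanging 2-nitrophenyl for 3-chlorophenyl on the double-bonded chain carbon stays within the scatter (a 2.0-fold higher number from compound 3 to compound 4 (0.30 log units; within the scatter)), so this second exchange of the whole aryl group also fails to separate the compounds.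

On these data alone, whether an amine, a carboxylic acid or a longer chain on this phenyl ring would move the number beyond the scatter remains open. No measurement shown here speaks to the cause of the step away from phenoxy.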